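Compound 3 gains a sulfonyl: what compound 4 may show

The source may hold more compounds than are shown below. What is called first, only, known or untested is meant among the compounds shown, and "the series" means these compounds.

For the measured compounds named here, in an ADME assay on a cell-free system (serum, Homo sapiens) for metabolic stability, read by HPLC, tested at 250 uM (on this read-out lower numbers stand for a shorter-lived compound and higher numbers for a longer-lived compound), compound 3 `CC(=O)Oc1ccccc1C(=O)OCOC(=O)c1ccc(CCCO[N+](=O)[O-])cc1` gives 0.0317 h, the only actual number among the three compounds measured. Compound 1 `CC(=O)Oc1ccccc1C(=O)OCOC(=O)c1ccc([S+]([O-])CCCO[N+](=O)[O-])cc1` yields only a limit, < 0.0167 h. Compound 2 `CC(=O)Oc1ccccc1C(=O)OCOC(=O)c1ccccc1OCCCO[N+](=O)[O-]` also yields only a limit, < 0.0167 h.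

Compound 4 `CC(=O)Oc1ccccc1C(=O)OCOC(=O)c1ccc(S(=O)(=O)CCCO[N+](=O)[O-])cc1` has not yet been measured. It departs from compound 3 by (3-(nitrooxy)propyl)sulfonyl in place of 3-(nitrooxy)propyl on an aromatic carbon, with (3-(nitrooxy)propyl)sulfonyl in place of 3-(nitrooxy)propyl on an aromatic carbon, para to a large group.

Going by the values given here, one measured step bears on this change, since it also links a sulfur-bearing group with the plain chain: an at least 1.8-fold higher number from compound 1 to compound 3 (0.27 log units; that floor lies within the scatter). Its size is bounded by the limit of < 0.0167 h in this assay, at which 2 of the 3 values shown sit, so it gives a floor and no exact figure. On that step, the expected change is a 1.9-fold lower number from compound 3 to compound 4 (0.27 log units; within the scatter), a modest move toward a shorter life, of about the size of the scatter, and a reading reported only as a limit would be quite possible. Compound 4 is estimated at 0.017 h in this assay, with an expected range of 0.009 h to 0.032 h.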

Compound 4, half-life in the serum assay: < 0.0167 h
Compound 4: only a limit was reported; the forecaster's own chance of this, stated with the estimate: 60%; middle value at least 1.0-fold (0.00 log units) from the limit.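

In the serum assay, placing (3-(nitrooxy)propyl)sulfonyl on this aromatic carbon gives an at least 1.8-fold lower number from compound 3 to compound 4 (0.27 log units; that floor lies within the scatter), so both sulfur-bearing groups at this position now end at a limit, and only the plain 3-(nitrooxy)propyl chain of compound 3 returns a readable half-life. In a physicochemical assay for metabolic stability, read by HPLC, with a stated time of 3 h, at pH 1, tested at 0.5 mM (on this read-out higher numbers stand for a more stable compound and lower numbers for a less stable compound), the same change gives no change at the digits printed from compound 3 to compound 4 (within the scatter). In the physicochemical assay compound 3 gives 98% and compound 4 gives 98%. The step in the serum assay is only a floor, and the step between compound 1 and compound 4 cannot be read, because the readings sit at the assay's limit: the limit of < 0.0167 h in the serum assay, at which 3 of the 4 values shown sit.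

The true half-life of compound 4 stays open, so the compounds shown cannot rank it against compound 1. Also open, from the compounds shown here alone, is whether an amine, a carboxylic acid or a longer chain on this aromatic carbon would give a half-life that can be read.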